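Compound 1 to compound 4: ethyl in place of chloro

The source may report more compounds than this note shows. Statements on the series, on what has been measured and on what is new or still open speak of the compounds shown alone.

In an ADME assay on J774 cells (Mus musculus) for cytotoxicity (on this read-out lower numbers stand for an effect already at smaller amounts and higher numbers for an effect only at larger amounts of compound), compound 1 `COC(=O)c1c[nH]c2cc(OCCOc3ccccc3)c(Cl)cc2c1=O` gives > 20000 nM, which is a limit of the assay and not a number. Compound 3 `CCOc1ccc2[nH]cc(C(=O)OC)c(=O)c2c1` gives > 20000 nM, also a limit. Compound 1 therefore stands at the limit of > 20000 nM in this assay, at which 2 of the 3 values shown sit. Compound 2 `COC(=O)c1c[nH]c2cc(OCc3ccccc3)ccc2c1=O` is the only one of the measured set with a number, 18900 nM.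

Compound 4 `CCc1cc2c(=O)c(C(=O)OC)c[nH]c2cc1OCCOc1ccccc1` is still unmeasured in this assay. It has ethyl in place of chloro on an aromatic carbon, ortho to a large group, and the rest of compound 1 is unchanged. Among the compounds with values here, no pair of measured compounds differs in one place only, so no measured step guides this change. The expectation rests on the limit of compound 1, > 20000 nM, and no step beyond the scatter is expected in this assay. The expected change is a number no higher from compound 1 to compound 4 (the limit leaves the size open). For compound 4 the estimate is 20000 nM, with an expected range from 9000 nM to 40000 nM.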

Compound 4, half-maximal effective concentration: > 20000 nM
Compound 4: no number, only a limit (the forecaster's own chance of this, stated with the estimate: 65%); the middle value lies on the limit itself.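

In this assay compound 4 gives > 20000 nM, a limit and not a number. Compound 1 also stands at a limit, so no step can be read between compound 1 and compound 4. The compounds shown leave open whether ethyl in place of chloro changes this read-out at all.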